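The source may hold more compounds than are shown below. What is called first, only, known or untested is meant among the compounds shown, and "the series" means these compounds.

Of the compounds shown here, three that share one core have been measured in a physicochemical assay for acid dissociation. Compound 1 `C#CC(C)OC[n+]1ccn(C)c1/C=N/O` gives 7.96, compound 2 `CC#CC(C)OC[n+]1ccn(C)c1/C=N/O` gives 8.03, and compound 3 `C#CCC(C)OC[n+]1ccn(C)c1/C=N/O` gives 8.03. Compound 3 thus stands level with compound 2 and within the usual scatter of compound 1.

The next compound, compound 4 `C#CC(C)C(C)OC[n+]1ccn(C)c1/C=N/O`, differs from compound 3 in one place: methyl in place of hydrogen on a saturated chain carbon bound to a saturated chain carbon and a triple-bonded carbon. In words, this is methyl in place of hydrogen on a saturated chain carbon bound to a saturated chain carbon and a triple-bonded carbon.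

The closest evidence comes from small changes in the same chain. Methyl in place of hydrogen on a triple-bonded carbon gave a number 0.07 log units higher from compound 1 to compound 2 (within the scatter). Propargyl in place of ethynyl gave a number 0.07 log units higher from compound 1 to compound 3 (within the scatter). Propargyl in place of prop-1-yn-1-yl gave no change at the digits printed from compound 2 to compound 3 (within the scatter). None of these steps leaves the scatter, so none beyond it is expected for this added methyl.

The expected step is no change at the digits printed from compound 3 to compound 4 (within the scatter). Compound 4 is estimated at 8.03, with an expected range from 7.85 to 8.2.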

Compound 4, acid dissociation constant: 8
Compound 4: middle estimate off by 0.03 log units, on the high side, within the range that was stated.
By their numbers in this assay, from the lowest: compounds 1, 4, 2 and 3 (each within the scatter of the next).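

In this assay, among these compounds, methyl in place of hydrogen on a saturated chain carbon bound to a saturated chain carbon and a triple-bonded carbon gives a number 0.03 log units lower from compound 3 to compound 4 (within the scatter) and so adds a position that the earlier steps did not touch, again without leaving the scatter. Bringing in 1-methylprop-2-yn-1-yl reads the same way, in place of prop-1-yn-1-yl with a number 0.03 log units lower from compound 2 to compound 4 (within the scatter) and in place of ethynyl with a number 0.04 log units higher from compound 1 to compound 4 (within the scatter) as its step, so all steps among these four compounds now lie within the scatter. Nothing measured here speaks to the reason for this flat picture.

All four compounds carry a chain with a triple bond. As far as these compounds go, whether an amine, a carboxylic acid or a longer chain on this same carbon would stay within the scatter in this assay or move beyond it remains open.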